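Changing the Aryl Group on the Ring Nitrogen

A few compounds are considered here, and "the series" means these few. Any claim that something is new, unique, unknown or untested is made for them only; others in the source may bear on it.

Two measured compounds share one core and differ only in the aryl group attached to an aromatic nitrogen. Compound 1 `CCc1cccc(C)c1-n1nncc1CN1C(=O)C2(C(C#N)=C(N)Oc3c(N)cc4nc5ccccc5nc4c32)c2ccccc21` carries a 2-ethyl-6-methylphenyl there. In an ADME assay on HUVEC cells (Homo sapiens) for antiproliferative activity, read by MTT assay, with a stated time of 48 h (on this read-out higher numbers stand for weaker inhibition and lower numbers for stronger inhibition), compound 1 gives > 50000 nM, which is a limit of the assay rather than a number. Compound 2 `N#CC1=C(N)Oc2c(N)cc3nc4ccccc4nc3c2C12C(=O)N(Cc1cnnn1-c1cc(Cl)ccc1Cl)c1ccccc12` carries a 2,5-dichlorophenyl in its place. In this assay compound 2 gives > 50000 nM, again a limit and not a number. The step that the two limits leave unreadable from compound 1 to compound 2 therefore cannot be read, as both of its ends rest on (the limit of > 50000 nM in this assay, at which 2 of the 2 values shown sit). Where compound 2 stands is thus known only as a limit, and the one further value shown is a limit as well.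

Compound 3 `N#CC1=C(N)Oc2c(N)cc3nc4ccccc4nc3c2C12C(=O)N(Cc1cnnn1-c1ccc(Cl)cc1[N+](=O)[O-])c1ccccc12` changes compound 2 by 4-chloro-2-nitrophenyl in place of 2,5-dichlorophenyl on an aromatic nitrogen. Among the compounds with values here, the only measured step at this position, a step that the two limits leave unreadable from compound 1 to compound 2, has no readable size, so neither direction nor magnitude can be taken from it. With both measured compounds sitting at the limit of > 50000 nM in this assay, at which 2 of the 2 values shown sit, compound 3 is expected to sit there too, with a step that the limit leaves unreadable from compound 2 to compound 3 that is not expected to go beyond the scatter. In this assay compound 3 is estimated at 60000 nM, most likely reported as a limit, within a range from 20000 nM to 200000 nM.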

Compound 3, half-maximal inhibitory concentration: > 50000 nM
Compound 3: only a limit was reported (the forecaster's own chance of this, stated with the estimate: 85%); the middle value is on the limit's open side.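

Compound 3 gives > 50000 nM in this assay, which is again a limit and not a number. Its steps from compound 1 and compound 2 therefore cannot be read, because all three compounds share the same result: the limit of > 50000 nM in this assay, at which 3 of the 3 values shown sit. The compounds shown leave open how these three aryl groups rank against one another, and whether any group at this place gives a measurable value.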